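The source may report more compounds than this note shows. Statements on the series, on what has been measured and on what is new or still open speak of the compounds shown alone.

Working notes on the series. Three compounds have numbers in an assay on HEK293 cells for agonist activity at transient receptor potential cation channel subfamily M member 8 (Homo sapiens), read by fluorescence and calcium flux, with a stated time of 15 min; on this read-out higher numbers stand for an effect only at larger amounts of compound and lower numbers for an effect already at smaller amounts. Compound 1 `CCN(Cc1ccoc1)C(=O)COc1ccc(C)cc1` gives 136 nM in this assay, the second highest of the three numbers. Compound 2 `CCc1ccc(OCC(=O)N(CC)Cc2cccs2)cc1` gives 67 nM, the nearest number, lower than that of compound 1 and beyond the scatter. Compound 3 `Cc1ccc(OCC(=O)N(Cc2cccs2)C2COC2)cc1` gives 23000 nM, the furthest number, far higher than that of compound 1 and beyond the scatter. No two of these compounds differ in one place only, so no single step can be read from the measured set; the numbers show only that compound 1 and compound 2 lie close together while compound 3 stands far apart from both.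

Compound 4 `CCN(Cc1nccs1)C(=O)COc1ccc(C)cc1` has not been measured. It differs from compound 1 in one place: 1,3-thiazol-2-yl in place of furan-3-yl on a saturated chain carbon bound to an amide-type nitrogen. Nothing measured shows this exchange, so the expectation rests on compound 1 alone. Because compound 1 gives 136 nM and the change keeps a five-membered aromatic ring at the same place, the step from compound 1 to compound 4 is expected to be small, a 1.3-fold higher number from compound 1 to compound 4 (0.12 log units; within the scatter), not beyond the scatter in either direction. Compound 4 is estimated at 180 nM in this assay, within a range from 45 nM to 900 nM.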

Compound 4, half-maximal effective concentration: 3060 nM
The estimate for compound 4 lay 17-fold (1.23 log units) below the measured number; measured number above the stated range.
By their numbers in this assay, from the lowest: compound 2; then compound 1; then compound 4; then compound 3.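

In this assay, a 23-fold higher number from compound 1 to compound 4 (1.35 log units; beyond the scatter) comes with 1,3-thiazol-2-yl in place of furan-3-yl on a saturated chain carbon bound to an amide-type nitrogen, so at this place one five-membered aromatic ring cannot stand in for another without a large change in the number. The two groups match in heavy-atom count, in ring size and in having no net charge, which shows that these shared features do not fix the number here; they differ in hetero atoms and in hydrogen-bond acceptor count. No measurement at hand ties the step to any one of these differences.

The compounds shown leave open whether the step follows the ring nitrogen, the sulfur or the point of attachment of the ring. They also leave open how 1,3-oxazol-2-yl or a plain phenyl ring would read at this place on the core of compound 1.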